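The source may hold more compounds than are shown below. What is called first, only, known or untested is meant among the compounds shown, and "the series" means these compounds.

Compound 3 `O=C(Nc1ccc(C(F)(F)F)cc1)C1NCCc2ccccc21` gives 4220 nM in a functional assay on NUGC-3 cells (Homo sapiens) for inhibition, read by sulforhodamine B assay, with a stated time of 48 h; on this read-out higher numbers stand for weaker inhibition of growth and lower numbers for stronger inhibition of growth. Compound 2 `COc1ccc(NC(=O)C2NCCc3ccccc32)cc1` differs from it by methoxy in place of trifluoromethyl on an aromatic carbon. In this assay compound 2 gives > 10000 nM, which is a limit of the assay and not a number. The step of an at least 2.3-fold higher number from compound 3 to compound 2 (0.37 log units; beyond the scatter) is thus at least modest, toward weaker inhibition. Compound 1 `O=C(Nc1ccc(C(F)(F)F)cc1)c1nccc2ccccc12` has a different core; how the two cores differ is not broken down here. In this assay compound 1 gives > 10000 nM, again a limit of the assay. Compound 4 `COc1ccc(NC(=O)c2nccc3ccccc23)cc1` is not yet measured and differs from compound 1 by methoxy in place of trifluoromethyl on an aromatic carbon, the same change made between the two measured compounds. Because compound 1 already sits at the limit of > 10000 nM in this assay, at which 2 of the 3 values shown sit, the step that the limit leaves unreadable from compound 1 to compound 4 is expected to leave compound 4 no stronger. Compound 4 is therefore estimated at 25000 nM, between 8000 nM and 80000 nM.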

Compound 4, concentration for 50% growth inhibition: > 10000 nM
Compound 4: no number, only a limit; the forecaster's own chance of this, stated with the estimate: 85%; the middle value lies beyond the limit too.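

No step can be read from compound 1 to compound 4, since both results in this assay are limits and not numbers: the limit of > 10000 nM in this assay, at which 3 of the 4 values shown sit.

The compounds shown leave open whether methoxy in place of trifluoromethyl changes growth inhibition on the core of compound 1.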